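The source may hold more compounds than are shown below. What is called first, only, known or untested is meant among the compounds shown, and "the series" means these compounds.

Measured compounds:
compound 1 `Oc1cc(C(F)(F)F)ccc1-c1nc(-c2ccccc2O)n(-c2ccc(Br)cc2)n1` — 100%
compound 2 `COc1ccccc1-n1nc(-c2ccc(C(F)(F)F)cc2O)nc1-c1ccccc1O` — 96.2%

In a functional assay on PC-12 cells (Rattus norvegicus) for cytotoxicity, read by MTT assay, with stated times of 2 h and 24 h, tested at 10 uM (on this read-out higher numbers stand for a stronger effect at the one concentration tested and lower numbers for a weaker effect), compound 2 stands lowest of the two numbers, with compound 1 nearest to it. For the measured compounds named here, the only measured step, a number 3.8 percentage points lower from compound 1 to compound 2 (within the scatter), also exchanges the group on the aromatic nitrogen and stayed within the scatter. Compound 3 `Cc1ccc(-n2nc(-c3ccc(C(F)(F)F)cc3O)nc2-c2ccccc2O)c(C)c1` differs from compound 2 by 2,4-dimethylphenyl in place of 2-methoxyphenyl on an aromatic nitrogen. As the step from compound 1 to compound 2 bears on this change and was within the scatter, no step beyond the scatter is expected for a number 1.2 percentage points lower from compound 2 to compound 3 (within the scatter). Compound 3 is therefore estimated at 95%, with a range from 80% to 105%.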

Compound 3, a percentage reported as activity, at one concentration (the size of the read-out at that concentration, not a potency): 106%
Compound 3: middle estimate off by 11 percentage points, on the low side, and the stated range ends below it.
By their numbers in this assay, from the lowest: compounds 2, 1 and 3 (each within the scatter of the next).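

In this assay the exchange of 2-methoxyphenyl for 2,4-dimethylphenyl gives a number 9.8 percentage points higher from compound 2 to compound 3 (within the scatter) and the exchange of 4-bromophenyl for the same group gives a number 6 percentage points higher from compound 1 to compound 3 (within the scatter) so all three aryl groups on this aromatic nitrogen now lie within the scatter of one another. This holds even with 0 hydrogen-bond acceptors in the entering group against 1 in 2-methoxyphenyl. No measurement shown here offers an explanation for this result. From the compounds shown here alone, all three groups are substituted phenyl rings, so whether an amine, a carboxylic acid or a longer alkyl chain on this nitrogen would keep the read-out within the scatter stays open.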